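The compounds below may be only part of what the source reports. "The series", "measured", "known", "first", "only" and "open" are said of these compounds alone.

Among the compounds with values here, in a functional assay (strain AB) with Danio rerio as the target, read by microscopy, with a stated time of 1 h (on this read-out higher numbers stand for an effect only at larger amounts of compound and lower numbers for an effect already at smaller amounts), compound 1 `NC(=O)c1c(NC(=O)Nc2ccc(Cl)cc2)sc2c1CCN(C1CCOCC1)C2` gives 2830 nM, the only actual number so far. Compound 2 `CCN1CCc2c(sc(NC(=O)Nc3ccc(Cl)cc3)c2C(=O)OC)C1` gives > 25000 nM, which is a limit. Compound 3 `CC(C)CN1CCc2c(sc(NC(=O)Nc3ccc(Cl)cc3)c2C(N)=O)C1` keeps the core of compound 1 and carries isobutyl in place of oxan-4-yl on an amine nitrogen in a ring. Within the data shown here, no measured step covers this change, so the expectation has no direct support. The expected step of a 1.3-fold lower number from compound 1 to compound 3 (0.11 log units; within the scatter) is estimated as small, probably not beyond the scatter, with only a slight lean towards lower numbers. For compound 3 the estimated value is 2200 nM, with an expected range from 700 nM to 9000 nM.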

Compound 3, half-maximal effective concentration: 4510 nM
Estimate against measurement, compound 3: 2.1-fold (0.31 log units) below; the measured number falls inside the stated range.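

On the amine nitrogen in the ring, replacing oxan-4-yl with isobutyl in this assay gives a 1.6-fold higher number from compound 1 to compound 3 (0.20 log units; within the scatter), so the step stays small. For this pair, neither the non-aromatic ring nor its oxygen on this nitrogen is needed to keep the number within the scatter. Compound 2 remains a limit of the assay and gives no readable step: the limit of > 25000 nM in this assay, at which 1 of the 3 values shown sits.

Open, going by these compounds, is whether methyl, or a chain ending in an amine or a carboxylic acid, on this nitrogen would move the number beyond the scatter. On these data alone, the separate contribution of the methyl ester in compound 2 also remains open.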